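The compounds below may be only part of what the source reports. "The series", "measured", "known", "first", "only" and "open" are said of these compounds alone.

Compound 1 `C/C(=N\NC(=O)COc1cccc2ccccc12)c1ccc(C#N)cc1Br` gives 3.61. Compound 2 `O=C(COc1cccc2ccccc12)N/N=C/c1ccc(O)cc1` gives 3.73. Compound 3 `O=C(COc1cccc2ccccc12)N/N=C/c1cccc([N+](=O)[O-])c1` gives 3.97.

The three measured compounds share a core and differ only in the aromatic group attached to the carbon with a double bond to nitrogen. They were tested in a physicochemical assay for lipophilicity, measured as octanol-water partition; a lower number here means a more polar compound, a higher number a more lipophilic compound. In this assay compound 1 gives 3.61, which sits within the scatter of the value of compound 2, while compound 3 gives 3.97, a value that stands beyond the scatter above compound 1.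

Compound 4 `C/C(=N\NC(=O)COc1cccc2ccccc12)c1ccccc1O` has not been measured in this assay. Its structure is drawn from compound 1 by a single exchange: 2-hydroxyphenyl in place of 2-bromo-4-cyanophenyl on a carbon with a double bond to nitrogen.

Within the data shown here, no measured pair shows exactly this exchange, so the expectation rests on the values in hand. Because compound 2, which also carries a hydroxyphenyl, gives 3.73, the step from compound 1 to compound 4 is expected to be small, a number 0.11 log units lower from compound 1 to compound 4 (within the scatter), and not clearly beyond the scatter. Compound 4 is therefore estimated at 3.5, with a range from 3 to 4.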

Compound 4, partition coefficient: 3.08
Beside the measured number, compound 4's estimate is 0.42 log units above it; measured number inside the range.
By their numbers in this assay, from the lowest: compound 4; then compounds 1, 2 and 3 (each within the scatter of the next, the first and the last beyond it).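

Among these compounds, the exchange of 2-bromo-4-cyanophenyl for 2-hydroxyphenyl gives the first reading of a single change on this carbon with a double bond to nitrogen: in this assay, the result is a number 0.53 log units lower from compound 1 to compound 4 (beyond the scatter). It is a combined change, since the group that leaves carries a bromine and a nitrile and no hydrogen-bond donor, while the group that enters carries one hydrogen-bond donor and neither of the other two. No measurement at hand explains the size of this step.

The compounds shown leave open how much of the step belongs to the loss of the bromine, the loss of the nitrile or the arrival of the hydroxy group. They also leave open how an amine, a carboxylic acid or a longer chain in this place would read in this assay.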